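This account rests on a few compounds, and the source may have more. Where it says the series, first, only, none or still open, it means among the compounds named here.

Measured so far in a functional assay on OVCAR-8 cells (Homo sapiens) for cytotoxicity, read by sulforhodamine B assay, with a stated time of 48 h; a lower number here means a stronger inhibitor of growth, a higher number a weaker inhibitor of growth: compound 1 `ClCc1ccc(Cn2cnc3c(Cl)ncnc32)cc1` gives 3020 nM; compound 2 `ClCc1ccc(Cn2cnc3nc(Cl)nc(Cl)c32)cc1` gives 1990 nM; compound 3 `ClCc1ccc(Cn2cnc3c(Cl)nc(Cl)nc32)cc1` gives 20000 nM.

Compound 3 and compound 1 differ in one place, (hydrogen in place of chloro on an aromatic carbon). That step is a 6.6-fold lower number from compound 3 to compound 1 (0.82 log units; beyond the scatter). Compound 2 has the same atoms as compound 3 joined differently; the difference between the two cores is not broken down here. Compound 2 and compound 1 lie within the scatter of each other, while compound 2 sits well apart from compound 3.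

Compound 4 `ClCc1ccc(Cn2cnc3ncnc(Cl)c32)cc1` is not yet measured in this assay. It differs from compound 2 by hydrogen in place of chloro on an aromatic carbon, which is the same change as that from compound 3 to compound 1, at a place described in the same words. For compound 4 a step of a 3.1-fold lower number from compound 2 to compound 4 (0.49 log units; beyond the scatter) is expected from compound 2, resting on the earlier step, because a 6.6-fold lower number from compound 3 to compound 1 (0.82 log units; beyond the scatter) was seen on a core that is joined differently, so a smaller move is estimated. Compound 4 is therefore estimated at 650 nM, expected between 200 nM and 2000 nM.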

Compound 4, concentration for 50% growth inhibition: 3160 nM
Compound 4: middle estimate off by 4.9-fold (0.69 log units), on the low side, and the stated range ends below it.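

In this assay, putting hydrogen in place of chloro on the aromatic carbon between two ring nitrogen atoms gives a 1.6-fold higher number from compound 2 to compound 4 (0.20 log units; within the scatter), a step that does not separate the two compounds. Set beside the earlier step, the same change does not carry over with the same size from one core to the other: the same change on two cores in this assay, a 6.6-fold lower number (0.82 log units; beyond the scatter) from compound 3 to compound 1 and a 1.6-fold higher number (0.20 log units; within the scatter) from compound 2 to compound 4, 11-fold (1.02 log units) apart, beyond the scatter of two such steps. This shows that, for these two pairs, the size of the step depends on the core that carries it, but it does not show what in the cores sets the gap, and two pairs give no rule for any further core in the series.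

The compounds shown leave open how an amine, a methoxy group or a thioether would behave on that same aromatic carbon, as only chloro and hydrogen appear there. They also leave open whether the chloromethyl group could give way to a hydroxymethyl group or a longer chain on either core.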